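Ester replaced by an aminoester-bearing methyl on fluorinated core

This account rests on a few compounds, and the source may have more. Where it says the series, first, only, none or still open, it means among the compounds named here.

Compound 3 `CCOC(=O)c1c(F)c(N)c2c(=O)cc(-c3ccc(N)c(F)c3)oc2c1F` reaches only the limit of a functional assay on HeLa cells (Homo sapiens) for cytotoxicity, read by neutral red uptake, with a stated time of 3 days (on this read-out lower numbers stand for stronger inhibition and higher numbers for weaker inhibition), giving > 100000 nM. Compound 1 `COc1c(F)c(N)c2c(=O)cc(-c3ccc(N)c(F)c3)oc2c1F` gives 34000 nM in this assay, and compound 2 `Nc1ccc(-c2cc(=O)c3c(N)c(F)c(N)c(F)c3o2)cc1F` gives 19000 nM; the step of a 1.8-fold lower number from compound 1 to compound 2 (0.25 log units; within the scatter) lies within the scatter. Compound 3 thus stands at the weak end of the three, as shown by an at least 2.9-fold higher number from compound 1 to compound 3 (0.46 log units; beyond the scatter) and an at least 5.2-fold higher number from compound 2 to compound 3 (0.72 log units; beyond the scatter), both resting on (the limit of > 100000 nM in this assay, at which 1 of the 3 values shown sits). Compound 4 `CN(C)CCCC(=O)OCc1c(F)c(N)c2c(=O)cc(-c3ccc(N)c(F)c3)oc2c1F` differs from compound 3 by (((3-(dimethylamino)propyl)carbonyl)oxy)methyl in place of ethoxycarbonyl on an aromatic carbon. Among the compounds with values here, no measured step replaces ethoxycarbonyl by another group, so the direction is open; the two steps into compound 3 show only that ethoxycarbonyl at this position gave a higher number than methoxy or amino. Compound 4 is therefore estimated at 70000 nM, within 20000 nM to 300000 nM, a step of an at least 1.4-fold lower number from compound 3 to compound 4 (0.15 log units; that floor lies within the scatter) that is expected to stay within the scatter or to end at a limit again.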

Compound 4, half-maximal inhibitory concentration: 4500 nM
Compound 4: middle estimate off by 16-fold (1.19 log units), on the high side, and the stated range ends above it.
By their numbers in this assay, from the lowest: compound 4; then compounds 2 and 1 (each within the scatter of the next). At a limit, above all of these: compound 3.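

In this assay, this position proves able to carry a group that moves the number down as well as up, and the largest step rests on a limit, an at least 22-fold lower number from compound 3 to compound 4 (1.34 log units; beyond the scatter): the limit of > 100000 nM in this assay, at which 1 of the 4 values shown sits. The (((3-(dimethylamino)propyl)carbonyl)oxy)methyl group also goes beyond the scatter against the two smaller groups, with a 4.2-fold lower number from compound 2 to compound 4 (0.63 log units; beyond the scatter) and a 7.6-fold lower number from compound 1 to compound 4 (0.88 log units; beyond the scatter). Which part of this group carries these steps stays open: the dimethylamino end, the ester link or the chain length. As far as these compounds go, how a hydroxymethyl group, or an amide in place of the ester link, would read at this position also remains unknown.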